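Changing the acyl ring on a tert-butyl compound

The source may report more compounds than this note shows. Statements on the series, on what has been measured and on what is new or still open speak of the compounds shown alone.

In a functional assay on MDA-MB-436 cells (Homo sapiens) for antiproliferative activity, read by MTT assay, with a stated time of 24 h (on this read-out higher numbers stand for weaker inhibition and lower numbers for stronger inhibition), compound 1 (`COc1ccccc1C(=O)NC(CC(=O)O)c1ccccc1`) gives > 100000 nM as a limit of the assay and not a number. Compound 2 (`COc1ccccc1C(=O)NC(CC(=O)O)c1ccc(C(C)(C)C)cc1`), which has tert-butyl in place of hydrogen on an aromatic carbon, gives > 100000 nM as a limit as well. Compound 2 therefore stands only at a limit, and the limit of > 100000 nM in this assay, at which 2 of the 2 values shown sit, holds for both measured compounds. The next compound to read is compound 3 (`CC(C)(C)c1ccc(C(CC(=O)O)NC(=O)c2c(Cl)cccc2Cl)cc1`), where the change is 2,6-dichlorophenyl in place of 2-methoxyphenyl on a carbonyl carbon in short, 2,6-dichlorophenyl in place of 2-methoxyphenyl on a carbonyl carbon. Within the data shown here, the one measured step is a step that the two limits leave unreadable from compound 1 to compound 2 and it has no readable size to carry forward. Among the measured compounds shown here, it also lies at a different place, so no measured step bears directly on this change. No direction can be drawn from the data, and the expectation rests on the limit shared so far. The expected step is a number no higher from compound 2 to compound 3 (the limit leaves the size open) in this assay and no shift beyond the scatter is expected. For compound 3 the estimate is 100000 nM with an expected range of 30000 nM to 300000 nM and a further limit as the likeliest report.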

Compound 3, half-maximal inhibitory concentration: > 100000 nM
Compound 3: a limit, no number; the forecaster's own chance of this, stated with the estimate: 75%; the middle value lies on the limit itself.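

In this assay compound 3 gives > 100000 nM, a limit of the assay and not a number. The step from compound 2 to compound 3 therefore cannot be read, and the series stays at one shared limit: the limit of > 100000 nM in this assay, at which 3 of the 3 values shown sit.

The compounds shown leave open whether any change to this series gives a measurable value in this assay.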